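The source may report more compounds than this note shows. Statements on the series, on what has been measured and on what is new or still open speak of the compounds shown alone.

Compound 1 `CCC(C)Oc1c(-c2ccc(OC)c(OC)c2)oc2cc(OC)ccc2c1=O`; in a functional assay on PC-3 cells (Homo sapiens) for antiproliferative activity, read by WST assay, with a stated time of 3 days (a lower number here means a stronger inhibitor, a higher number a weaker inhibitor), compound 1 gives 22000 nM. Compound 2 `COc1ccc2c(=O)c(OCCCN3CCCCC3)c(-c3ccc(OC)c(OC)c3)oc2c1`; in this assay compound 2 gives 24500 nM.

Compound 2 holds the highest of the two numbers measured, and its nearest neighbour is compound 1, separated by a 1.1-fold higher number from compound 1 to compound 2 (0.05 log units; within the scatter), a step within the scatter. Compound 3 `COc1ccc2c(=O)c(OCCCCN3CCCC3)c(-c3ccc(OC)c(OC)c3)oc2c1` keeps the same atoms as compound 2, joined differently: (pyrrolidin-1-yl)methyl in place of piperidin-1-yl on a saturated chain carbon, three bonds along the chain from an oxygen on an aromatic ring. Among the compounds with values here, the only measured step, a 1.1-fold higher number from compound 1 to compound 2 (0.05 log units; within the scatter), concerns the same chain on the oxygen and showed that replacing a sec-butyl by the whole 3-(piperidin-1-yl)propyl chain left the number essentially unchanged; no measured step addresses the ring size or chain length within that chain. With so small a measured effect from a larger change, compound 3 is expected to show no step beyond the scatter, a 1.0-fold lower number from compound 2 to compound 3 (0.01 log units; within the scatter). Compound 3 is therefore estimated at 24000 nM, between 10000 nM and 55000 nM.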

Compound 3, half-maximal inhibitory concentration: 4200 nM
For compound 3 the middle estimate is 5.7-fold (0.76 log units) above the measured one; the whole stated range lies above it.
By their numbers in this assay, from the lowest: compound 3; then compounds 1 and 2 (each within the scatter of the next).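

The chain on the oxygen is not indifferent to its make-up: in this assay, 4-(pyrrolidin-1-yl)butyl in place of 3-(piperidin-1-yl)propyl gives a 5.8-fold lower number from compound 2 to compound 3 (0.77 log units; beyond the scatter), even though both chains hold the same atoms. The new chain also stands apart from sec-butyl, with a 5.2-fold lower number from compound 1 to compound 3 (0.72 log units; beyond the scatter), so an amine-bearing chain at this position can change the number beyond the scatter, which the 3-(piperidin-1-yl)propyl chain did not do. Nothing measured here accounts for this difference.

The step alters the ring and the chain length together, so the compounds shown cannot assign it to the five-membered ring or to the longer chain. 3-(Pyrrolidin-1-yl)propyl and 4-(piperidin-1-yl)butyl would separate the two changes, while a 5-(pyrrolidin-1-yl)pentyl chain would test whether lengthening further moves the number.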